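A 2,6-dimethoxyphenyl swap at the carbonyl of compound 3

The source may report more compounds than this note shows. Statements on the series, on what has been measured and on what is new or still open speak of the compounds shown alone.

In an ADME assay on MT4 cells (Homo sapiens) for cytotoxicity, read by MTT assay (a lower number here means that less compound is tolerated, a higher number that more compound is tolerated), three compounds sharing one core have been measured. Compound 1 `O=C1c2ccccc2C(=O)N1CCOC(=S)N(C(=O)c1ccc(C(F)(F)F)cc1)c1ccc(Cl)cc1` gives 10000 nM, and compound 3 `O=C1c2ccccc2C(=O)N1CCOC(=S)N(C(=O)c1ccc(Cl)c(Cl)c1)c1ccc(Cl)cc1` gives 35000 nM, the higher of the two actual numbers. Compound 2 `O=C1c2ccccc2C(=O)N1CCOC(=S)N(C(=O)c1ccc([N+](=O)[O-])cc1)c1ccc(Cl)cc1` gives no number but a limit, > 100000 nM.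

Compound 4 `COc1cccc(OC)c1C(=O)N(C(=S)OCCN1C(=O)c2ccccc2C1=O)c1ccc(Cl)cc1` carries 2,6-dimethoxyphenyl in place of the 3,4-dichlorophenyl of compound 3 on a carbonyl carbon, (2,6-dimethoxyphenyl in place of 3,4-dichlorophenyl on a carbonyl carbon). The measured steps in this part of the structure are a 3.5-fold higher number from compound 1 to compound 3 (0.54 log units; beyond the scatter), an at least 2.8-fold lower number from compound 2 to compound 3 (0.45 log units; beyond the scatter) and an at least 10-fold higher number from compound 1 to compound 2 (1.00 log units; beyond the scatter). All three lie beyond the scatter and are modest or at least modest, so changes here can move the number. Among the compounds with values here, they run in both directions, however, and no measured compound carries a methoxy group, so they indicate no direction for this swap. The expected change in this assay is no change at the digits printed from compound 3 to compound 4 (within the scatter), with no step beyond the scatter as the central expectation and a modest step either way remaining possible. Compound 4 is therefore estimated at 35000 nM, with an expected range from 11000 nM to 100000 nM.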

Compound 4, half-maximal cytotoxic concentration: 69000 nM
Compound 4: the middle estimate sits 2.0-fold (0.29 log units) below what was measured; the measured number falls inside the stated range.
By their numbers in this assay, from the lowest: compound 1; then compounds 3 and 4 (each within the scatter of the next). At a limit, above all of these: compound 2.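

In this assay, the only methoxy-bearing group shown at this carbonyl carbon cannot be told apart from the 3,4-dichlorophenyl of compound 3: a 2.0-fold higher number from compound 3 to compound 4 (0.29 log units; within the scatter). The same swap measured against the 4-(trifluoromethyl)phenyl group gives a clear difference, a 6.9-fold higher number from compound 1 to compound 4 (0.84 log units; beyond the scatter), so among the actual numbers compound 1 now stands alone at the low end, apart from both compound 3 and compound 4. Compound 2 is held only by a limit, and its step reads an at least 1.4-fold lower number from compound 2 to compound 4 (0.16 log units; that floor lies within the scatter), which fixes no order between the two: the limit of > 100000 nM in this assay, at which 1 of the 4 values shown sits.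

As far as these compounds go, what a single methoxy group, an amine or a carboxylic acid would give at this carbonyl carbon stays open. Within the data shown here, all four compounds vary only this group, so the effect of a change elsewhere in the shared core is open too.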